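From methylcarbamoyl to dimethylcarbamoyl: one added methyl

A few compounds are considered here, and "the series" means these few. Any claim that something is new, unique, unknown or untested is made for them only; others in the source may bear on it.

Measured so far in an in vitro ADME assay on microsomes from liver (Homo sapiens) for metabolic stability; on this read-out lower numbers stand for slow clearance and higher numbers for fast clearance

compound 1 (`CC[C@H](C)[C@@H]1C(=O)N[C@H](C2Cc3ccccc3C2)C(=O)N1[C@@H](C(=O)N(C)C)c1cnc(C)cc1C`) gives 9 mL.min-1.g-1
compound 2 (`CC[C@H](C)[C@@H]1C(=O)N[C@H](C2Cc3ccccc3C2)C(=O)N1[C@@H](C(=O)NC)c1cc(C)cnc1C`) gives 3 mL.min-1.g-1

Compound 2 stands at 3 mL.min-1.g-1 in this assay and holds the lower of the two numbers, with a gap up to compound 1 that lies beyond the usual scatter. Compound 3 (`CC[C@H](C)[C@@H]1C(=O)N[C@H](C2Cc3ccccc3C2)C(=O)N1[C@@H](C(=O)N(C)C)c1cc(C)cnc1C`) has not yet been measured. It departs from compound 2 in one place, methyl in place of hydrogen on an amide-type nitrogen and in words this is methyl in place of hydrogen on an amide-type nitrogen, which turns methylcarbamoyl into dimethylcarbamoyl. Among the measured compounds shown here, no measured pair differs in one place only, so the data give no direct size for such a change. The expectation therefore leans on the two values alone, and compound 1 at 9 mL.min-1.g-1 marks the highest number seen so far. A modest upward step is expected, one that may not clear the scatter. The step expected a 1.7-fold higher number from compound 2 to compound 3 (0.22 log units; within the scatter) is small and towards faster clearance. For compound 3 the estimated value is 5 mL.min-1.g-1 with an expected range from 2.5 mL.min-1.g-1 to 11 mL.min-1.g-1 in this read-out.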

Compound 3, intrinsic clearance in microsomes: 5 mL.min-1.g-1
Estimate against measurement, compound 3: no gap at the digits printed; the range from low to high includes it.
By their numbers in this assay, from the lowest: compounds 2, 3 and 1 (each within the scatter of the next, the first and the last beyond it).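

In this assay, the added methyl on the amide-type nitrogen now has a size of its own: the change gives a 1.7-fold higher number from compound 2 to compound 3 (0.22 log units; within the scatter), so methylcarbamoyl and dimethylcarbamoyl cannot be told apart on this read-out while 2,5-dimethylpyridin-3-yl stays in place. The group on the saturated chain carbon also gets its first direct reading, as 2,5-dimethylpyridin-3-yl in place of 4,6-dimethylpyridin-3-yl gives a 1.8-fold lower number from compound 1 to compound 3 (0.26 log units; within the scatter), so with dimethylcarbamoyl held constant these two groups cannot be told apart either. Neither single change therefore moves the number beyond the usual scatter in this series, and nothing at hand speaks to what lies behind either step.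

The compounds shown leave open whether the added methyl would give a step of similar size with 4,6-dimethylpyridin-3-yl in place, and how a primary carboxamide or an ethyl group on that nitrogen would read. They also leave open how an unsubstituted phenyl ring, or a pyridinyl group carrying methoxy, would read at the saturated chain carbon.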